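Growth inhibition notes: aryl change on compound 3

The compounds below may be only part of what the source reports. "The series", "measured", "known", "first", "only" and "open" are said of these compounds alone.

In a functional assay on MIA PaCa-2 cells (Homo sapiens) for inhibition, read by MTT assay, with a stated time of 48 h, tested at 10 uM (a higher number here means more inhibition of growth at the concentration tested, a lower number less inhibition of growth), compound 1 (`Cc1cc(=O)c2c(O)c(CN3CCCC3)c(O)c([C@H]3CCN(C)C[C@H]3O)c2o1`) gives 28% of inhibition and compound 2 (`Cc1cc(=O)c2c(O)c(CN3CCC(Cc4ccccc4)CC3)c(O)c([C@H]3CCN(C)C[C@H]3O)c2o1`) gives 18% of inhibition. Compound 3 (`Cc1oc2c([C@H]3CCN(C)C[C@H]3O)c(O)cc(O)c2c(=O)c1C(O)c1cccc(Cl)c1`) stands lowest of the three at 2% of inhibition, beyond the scatter from both others. Compound 4 (`Cc1oc2c([C@H]3CCN(C)C[C@H]3O)c(O)cc(O)c2c(=O)c1C(O)c1cc(F)cc(F)c1`) has 3,5-difluorophenyl in place of 3-chlorophenyl on a saturated chain carbon bound to an aromatic carbon and an oxygen on a saturated carbon. Going by the values given here, no measured pair shows a change of this kind. An expected step of a number 3 percentage points higher from compound 3 to compound 4 (within the scatter) within the scatter, with no direction favoured, is the working assumption. In this assay the expected value for compound 4 is 5% within an estimated range of 0% to 17% for now.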

Compound 4, percent growth inhibition at one concentration: 6%
Estimate against measurement, compound 4: 1 percentage points below; measured number inside the range.
By their numbers in this assay, from the lowest: compounds 3 and 4 (each within the scatter of the next); then compounds 2 and 1 (each within the scatter of the next).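

The swap to 3,5-difluorophenyl gives a number 4 percentage points higher from compound 3 to compound 4 (within the scatter) in this assay, so this assay does not tell these two aryl groups apart on the saturated chain carbon. Going by these compounds alone, this pair is the only reading of that place, and it covers only these two halogenated phenyl groups. No evidence bears on this result.

Going by these compounds, whether a phenyl group carrying an amine or a carboxylic acid, or a longer chain in place of (hydroxy)methyl, would read differently stays open. Compound 1 and compound 2 differ from this pair in more than one place, so they cannot settle it.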